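Series notes: aryl tail changes on the shared core

The source may hold more compounds than are shown below. What is called first, only, known or untested is meant among the compounds shown, and "the series" means these compounds.

Compound 1 `CC(C)c1onc(-c2c(Cl)cccc2Cl)c1COc1ccc(N(C)C(=O)c2ccc(C(=O)O)cc2)c(C(F)(F)F)n1` gives 36% in a functional assay on HEK293 cells for agonist activity at Bile acid receptor (Homo sapiens) (a higher number here means a larger maximal response, a lower number a smaller maximal response), and compound 2 `CC(C)c1onc(-c2c(Cl)cccc2Cl)c1COc1ccc(N(C)C(=O)c2cccc(C(=O)O)c2)c(C(F)(F)F)n1` gives 35%; the step of a number 1 percentage points lower from compound 1 to compound 2 (within the scatter). Compound 3 `CC(C)c1onc(-c2c(Cl)cccc2Cl)c1COc1ccc(N(C)Cc2ccc(C(=O)NS(C)(=O)=O)cc2)c(C(F)(F)F)n1` gives 64%, the highest of the three numbers, with compound 1 nearest and compound 2 furthest, both beyond the scatter.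

Compound 4 `CC(C)c1onc(-c2c(Cl)cccc2Cl)c1COc1ccc(N(C)Cc2ccc(OCCO)cc2)c(C(F)(F)F)n1` follows from compound 3 by 2-hydroxyethoxy in place of (methylsulfonyl)carbamoyl on an aromatic carbon. Going by the values given here, no measured step covers this exchange: the only single-point step, from compound 1 to compound 2, moves a carboxyphenyl position on a carbonyl carbon and stays within the scatter, so the direction of the new step rests on little. The step of a number 16 percentage points lower from compound 3 to compound 4 (beyond the scatter) is expected, downward and beyond the scatter. Compound 4 is estimated at 48%, within 25% to 75%.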

Compound 4, largest response reached (reported as efficacy), in percent of the reference or control that the assay uses: 43%
Compound 4: the middle estimate sits 5 percentage points above what was measured; low and high end bracket the measured number.
By their numbers in this assay, from the lowest: compounds 2, 1 and 4 (each within the scatter of the next); then compound 3.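

The exchange at this aromatic carbon, para to a large group, does matter in this assay: a number 21 percentage points lower from compound 3 to compound 4 (beyond the scatter) when 2-hydroxyethoxy replaces (methylsulfonyl)carbamoyl. With 4-(2-hydroxyethoxy)benzyl on the nitrogen, a number 8 percentage points higher from compound 2 to compound 4 (within the scatter) and a number 7 percentage points higher from compound 1 to compound 4 (within the scatter) both stay within the scatter, so compound 4 is not separated from either carboxyphenyl amide. No measurement at hand explains the drop.

Going by these compounds, whether a carboxylic acid, an amine or a longer chain at this aromatic carbon would keep the response of compound 3 remains open. No pair shown changes the link on the nitrogen alone.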